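This account rests on a few compounds, and the source may have more. Where it says the series, first, only, none or still open, it means among the compounds named here.

Compound 1, `COc1cccc([C@H]2O[C@H](CC(=O)NCCCCC(=O)O)C(=O)N(CC(C)(C)CO)c3ccc(Cl)cc32)c1OC`, stands at the top of the two numbers gathered so far in a functional assay on the whole organism for inhibition, with Rattus norvegicus as the target, at a dose of 10 mg/kg by the oral route; on this read-out lower numbers stand for less inhibition and higher numbers for more inhibition at the one dose given (going by the name of the read-out): in this assay compound 1 gives 50%. Going by the values given here, its only companion with a measurement, compound 2, `COc1cccc([C@H]2O[C@H](CC(=O)N3CCC(CC(=O)O)CC3)C(=O)N(CC(C)(C)COC(=O)C(C)C)c3ccc(Cl)cc32)c1OC`, gives 34% in this assay, and the gap between the two lies beyond the usual scatter of repeated measurements. Compound 2 differs from compound 1 in more than one place, so the two values say nothing about any single change.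

Compound 3, `COc1cccc([C@H]2O[C@H](CC(=O)NCC(=O)O)C(=O)N(CC(C)(C)CO)c3ccc(Cl)cc32)c1OC`, awaits measurement in this assay. It differs from compound 1 in one place only: carboxy in place of 3-carboxypropyl on a saturated chain carbon bound to an amide-type nitrogen. The acid group stays, but the chain that carries it on the carbamoyl side becomes shorter. Among the compounds with values here, no measured pair isolates such a shortening here, so the size of the step rests on nothing more than the two numbers above. Compound 3 is expected to give 42%, within a range from 22% to 62%. That estimate amounts to a step of a number 8 percentage points lower from compound 1 to compound 3 (within the scatter), a drop of modest size that could still fall within the scatter.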

Compound 3, a percentage reported as inhibition, in the whole organism at one dose (the size of the read-out at that dose, not a potency): 14%
Compound 3: middle estimate off by 28 percentage points, on the high side; the whole stated range lies above it.
By their numbers in this assay, from the lowest: compound 3; then compound 2; then compound 1.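

In this assay, going by these compounds alone, putting carboxy in place of 3-carboxypropyl on a saturated chain carbon bound to an amide-type nitrogen gives a number 36 percentage points lower from compound 1 to compound 3 (beyond the scatter), the first change in one place that can be read. It shows that this position is sensitive to the length of the chain carrying the acid: both compounds keep a carboxylic acid, yet having that group on the carbamoyl side does not by itself preserve the read-out at the one oral dose, so the longer (4-carboxybutyl)carbamoyl arm goes with the higher number in this pair. Nothing available explains the size of this drop.

Within the data shown here, this single pair gives only two chain lengths, so it leaves open whether a 2-carboxyethyl group would fall closer to compound 1 or compound 3, and whether a still longer chain such as 5-carboxypentyl would raise the read-out further or lower it. It also leaves open whether the acid itself matters on the longer chain, as a primary amide, a hydroxyl or an amine at the chain end would show.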